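The compounds below may be only part of what the source reports. "The series", "measured", "known", "first", "only" and "open" are said of these compounds alone.

Compound 1 `Cc1cc(Nc2cc(-c3ccccc3)[nH]n2)n2nc(SCC(=O)c3ccccc3)nc2n1` gives 4450 nM
Compound 2 `Cc1cc(Nc2cc(-c3ccccc3)[nH]n2)n2nc(SCc3cccc(Br)c3)nc2n1` gives 8900 nM
Compound 3 `C#CCSc1nc2nc(C)cc(Nc3cc(-c4ccccc4)[nH]n3)n2n1` gives > 50000 nM as a limit, not a number

These results come from a functional assay on PC-9 cells (Homo sapiens) for inhibition, read by MTT assay, with a stated time of 72 h (a lower number here means a stronger inhibitor, a higher number a weaker inhibitor), and nothing else. Compound 3 has no number, only the limit of > 50000 nM in this assay, at which 1 of the 3 values shown sits, as its standing.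

Compound 4 `Cc1cc(Nc2cc(-c3ccccc3)[nH]n2)n2nc(SCc3cccc4ccccc34)nc2n1` differs from it by naphthalen-1-yl in place of ethynyl on a saturated chain carbon bound to a sulfur in the same place, naphthalen-1-yl in place of ethynyl.

Going by the values given here, two measured steps bear on this change. Ethynyl replaced benzoyl in an at least 11-fold higher number from compound 1 to compound 3 (1.05 log units; beyond the scatter) and replaced 3-bromophenyl in an at least 5.6-fold higher number from compound 2 to compound 3 (0.74 log units; beyond the scatter) here. Between those two larger groups lies a 2.0-fold higher number from compound 1 to compound 2 (0.30 log units; within the scatter) as a further guide.

Reversing the ethynyl swap, a step of at least modest size towards a lower number is expected in this assay for this change. The expected step is an at least 6.6-fold lower number from compound 3 to compound 4 (0.82 log units; beyond the scatter) on this estimate. Compound 4 is estimated at 7500 nM with an expected range from 2500 nM to 25000 nM in this assay.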

Compound 4, half-maximal inhibitory concentration: 3950 nM
The estimate for compound 4 lay 1.9-fold (0.28 log units) above the measured number; measured number inside the range.
By their numbers in this assay, from the lowest: compounds 4, 1 and 2 (each within the scatter of the next, the first and the last beyond it). At a limit, above all of these: compound 3.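

In this assay, naphthalen-1-yl in place of ethynyl gives an at least 12-fold lower number from compound 3 to compound 4 (1.10 log units; beyond the scatter), so a second fused aromatic ring is tolerated at this position. Against 3-bromophenyl it gives a 2.3-fold lower number from compound 2 to compound 4 (0.35 log units; beyond the scatter), the only step beyond the scatter among the three larger groups, while against benzoyl it gives a 1.1-fold lower number from compound 1 to compound 4 (0.05 log units; within the scatter). The step from compound 3 starts from a limit, not a number: the limit of > 50000 nM in this assay, at which 1 of the 4 values shown sits.

The compounds shown leave open how an amine, a carboxylic acid or a longer chain in this place would read. They also leave open whether naphthalen-2-yl would match naphthalen-1-yl.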